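The compounds below may be only part of what the source reports. "The series", "measured", "known", "first", "only" and "open" are said of these compounds alone.

Compound 1 `COc1cc(-c2cc(/C=C/C(=O)c3ccc(N)cc3)[nH]n2)cc(OC)c1OC` gives 10500 nM in a functional assay on IGROV-1 cells (Homo sapiens) for inhibition, read by sulforhodamine B assay, with a stated time of 48 h; on this read-out lower numbers stand for stronger inhibition of growth and higher numbers for weaker inhibition of growth. Compound 2 `COc1ccc(C(=O)/C=C/c2cc(-c3cc(OC)c(OC)c(OC)c3)n[nH]2)cc1OC` gives 3410 nM in this assay, the lowest of the two numbers, with a 3.1-fold lower number from compound 1 to compound 2 (0.49 log units; beyond the scatter). Compound 3 `COc1cc(C(=O)/C=C/c2cc(-c3cc(OC)c(OC)c(OC)c3)n[nH]2)cc(OC)c1OC` differs from compound 2 by methoxy in place of hydrogen on an aromatic carbon. Within the data shown here, only the step from compound 1 to compound 2 touches the same aryl group on the carbonyl, and that change was modest; adding one further methoxy gives no measured step of its own here. Compound 3 is therefore expected to show a number close to compound 2, estimated at 3000 nM (range 1000 nM to 9000 nM), a step of a 1.1-fold lower number from compound 2 to compound 3 (0.06 log units; within the scatter) within the scatter.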

Compound 3, concentration for total growth inhibition: 10200 nM
The estimate for compound 3 lay 3.4-fold (0.53 log units) below the measured number, and the stated range ends below it.
By their numbers in this assay, from the lowest: compound 2; then compounds 3 and 1 (each within the scatter of the next).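

In this assay, methoxy in place of hydrogen on this aromatic carbon, ortho to a methoxy group, gives a 3.0-fold higher number from compound 2 to compound 3 (0.48 log units; beyond the scatter), so growth inhibition weakens. This shows that the position responds to a single added methoxy, which the earlier step, a swap of the whole aryl group, could not show. Nothing given here accounts for this loss.

On these data alone, whether hydroxy or a fluorine atom on this carbon would give a number closer to that of compound 2 or of compound 3 stays open.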